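Phenyl in place of ethyl on the sulfur

A few compounds are considered here, and "the series" means these few. Any claim that something is new, unique, unknown or untested is made for them only; others in the source may bear on it.

Compound 2 `CCSc1ncnc2c1ncn2[C@@H]1O[C@H](CO)[C@@H](O)[C@H]1O` gives 57500 nM in an assay on isolated protein for binding affinity to Equilibrative nucleoside transporter 1 (Homo sapiens) (on this read-out higher numbers stand for weaker inhibition and lower numbers for stronger inhibition), the highest of the two numbers seen. Within the data shown here, compound 1 `CC(C)(Sc1ncnc2c1ncn2[C@@H]1O[C@H](CO)[C@@H](O)[C@H]1O)c1ccccc1` gives 21400 nM, and the step of a 2.7-fold higher number from compound 1 to compound 2 (0.43 log units; beyond the scatter) is the only measured step that bears on the change. Compound 3 `OC[C@H]1O[C@@H](n2cnc3c(Sc4ccccc4)ncnc32)[C@H](O)[C@@H]1O` differs from compound 2 by phenyl in place of ethyl on a sulfur, bringing a six-membered aromatic ring of carbon back onto the sulfur, as compound 1 carries. Since compound 1 sits lower at 21400 nM, compound 3 is expected to show a modest step downward, a 2.3-fold lower number from compound 2 to compound 3 (0.36 log units; beyond the scatter), to an estimated 25000 nM with a range of 9000 nM to 70000 nM.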

Compound 3, half-maximal inhibitory concentration: 91200 nM
Beside the measured number, compound 3's estimate is 3.6-fold (0.56 log units) below it, and the stated range ends below it.
By their numbers in this assay, from the lowest: compound 1; then compounds 2 and 3 (each within the scatter of the next).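

In this assay, phenyl in place of ethyl on the sulfur leaves the number within the scatter (a 1.6-fold higher number from compound 2 to compound 3 (0.20 log units; within the scatter)), so an aromatic ring set directly on the sulfur does not by itself lower it. Compound 1 keeps the same ring on a 1-methyl-1-phenylethyl group and stands clearly apart from the phenyl compound (a 4.3-fold higher number from compound 1 to compound 3 (0.63 log units; beyond the scatter)), so the ring alone does not account for the number of compound 1. No evidence is available on what lies behind this difference. As far as these compounds go, it remains open whether benzyl on the sulfur, or a longer chain ending in an amine, would bring the number lower than that of compound 1.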